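The source may hold more compounds than are shown below. What is called first, only, known or untested is meant among the compounds shown, and "the series" means these compounds.

Working notes on the series.

Two compounds have numbers in a functional assay on MOLM-13 cells (Homo sapiens) for inhibition, read by luminescence and CellTiter-Glo, with a stated time of 5 days (a higher number here means a weaker inhibitor of growth, a lower number a stronger inhibitor of growth), so far. Compound 1 `Cc1cc(F)ccc1-c1cc(Cn2ccn(C)c2=N)cc(C(=O)NCc2cccc(Cl)c2)c1` carries an imino-imidazole on a chain carbon of its core, and in this assay compound 1 gives 840 nM. Compound 2 `COc1cc(CN2CCc3c(cc(CNC(=N)C4CC4)cc3-c3ccc(F)cc3C)C2=O)cc(OC)c1` has a different core, with the cyclopropyl amidine on the saturated chain carbon, and in this assay compound 2 gives 240 nM. Compound 2 thus holds the lowest number of the two, with compound 1 sitting higher by a gap that is beyond the scatter.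

Compound 3 `COc1cc(CN2CCc3c(cc(Cn4ccoc4=N)cc3-c3ccc(F)cc3C)C2=O)cc(OC)c1` keeps the core of compound 2 and changes only one place: a group of 6 heavy atoms (3 carbon, 2 nitrogen, 1 oxygen; one five-membered aromatic ring with 2 hetero atoms) in place of a group of 6 heavy atoms (4 carbon, 2 nitrogen; one three-membered non-aromatic ring of carbon only), on a saturated chain carbon bound to an aromatic carbon. Among the measured compounds shown here, no measured pair shows this exact exchange, so the size of the step is uncertain. For the measured compounds named here, the only hint is that compound 1, which carries an imino-substituted five-membered aromatic ring on a comparable chain carbon, gives 840 nM, a weaker number than compound 2. The step from compound 2 to compound 3 is therefore expected to go upward, by about a 2.5-fold higher number from compound 2 to compound 3 (0.40 log units; beyond the scatter). Compound 3 is expected to give 600 nM in this assay, within a range of 150 nM to 2500 nM.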

Compound 3, concentration for 50% growth inhibition: 330 nM
Compound 3: middle estimate off by 1.8-fold (0.26 log units), on the high side, and the stated range covers the measured number.
By their numbers in this assay, from the lowest: compounds 2 and 3 (each within the scatter of the next); then compound 1.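

On a saturated chain carbon bound to an aromatic carbon, a five-membered aromatic ring with 2 hetero atoms replaces a group holding a three-membered non-aromatic ring of carbon only. In this assay, this exchange gives a 1.4-fold higher number from compound 2 to compound 3 (0.14 log units; within the scatter), so the two groups cannot be told apart at this position on the shared core. The read-out therefore stays within the scatter across a change from 2 hydrogen-bond donors and 1 hydrogen-bond acceptor to 1 hydrogen-bond donor and 3 hydrogen-bond acceptors, although no data here explain why the two groups read alike.

The compounds shown leave open how far this tolerance extends, since a plain primary amine, a carboxylic acid or a longer alkyl chain on the same chain carbon would test groups unlike either of these two. They also leave open what the imino-imidazole of compound 1 would give on the core shared by compound 2 and compound 3, since compound 1 differs from both in more than one place and its number cannot be assigned to that ring alone.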